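The source may report more compounds than this note shows. Statements on the series, on what has been measured and on what is new or still open speak of the compounds shown alone.

Measured in a functional assay on HepG2 cells (Homo sapiens) for antiproliferative activity, read by MTT assay, with a stated time of 48 h; a lower number here means a stronger inhibitor, a higher number a weaker inhibitor:
- Compound 1 `COc1ccc(-c2ccc3c(c2)C(=O)C(=O)N3c2ccc(OC)cc2)cc1`: > 10000 nM, a limit
- Compound 2 `COc1ccc(-c2ccc3c(c2)C(=O)C(=O)N3Cc2ccccc2OC)cc1`: 130 nM
- Compound 3 `COc1ccc(-c2ccc3c(c2)C(=O)C(=O)N3Cc2cc(C)cc(C)c2)cc1`: 410 nM

Of the two values that are numbers rather than limits, compound 3 has the higher. Compound 4 `COc1ccc(-c2ccc3c(c2)C(=O)C(=O)N3Cc2ccc(C#N)cc2)cc1` carries 4-cyanophenyl in place of 3,5-dimethylphenyl on a saturated chain carbon bound to an amide-type nitrogen in a ring.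

The large steps of an at least 76-fold lower number from compound 1 to compound 2 (1.88 log units; beyond the scatter) and an at least 24-fold lower number from compound 1 to compound 3 (1.38 log units; beyond the scatter) both leave the 4-methoxyphenyl group, a change not made here. Among the measured compounds shown here, the nearest precedent is the modest 3.2-fold higher number from compound 2 to compound 3 (0.50 log units; beyond the scatter). In this assay, no step beyond the scatter is therefore expected, and no direction can be favoured. The estimated step is a 1.0-fold lower number from compound 3 to compound 4 (0.01 log units; within the scatter). For compound 4 the expected value is 400 nM, with an estimated range of 130 nM to 1300 nM.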

Compound 4, half-maximal inhibitory concentration: 1000 nM
Compound 4: middle estimate off by 2.5-fold (0.40 log units), on the low side; low and high end bracket the measured number.
By their numbers in this assay, from the lowest: compound 2; then compound 3; then compound 4. At a limit, above all of these: compound 1.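

On the saturated chain carbon bound to an amide-type nitrogen in a ring, 4-cyanophenyl separates from both earlier aryl groups in this assay (a 2.4-fold higher number from compound 3 to compound 4 (0.39 log units; beyond the scatter); a 7.7-fold higher number from compound 2 to compound 4 (0.89 log units; beyond the scatter)), so this position does not accept every aryl swap equally. The advantage of a benzyl group over 4-methoxyphenyl on the amide-type nitrogen in a ring extends to 4-cyanobenzyl (an at least 10-fold lower number from compound 1 to compound 4 (1.00 log units; beyond the scatter)). That step rests on a limit, not a number: the limit of > 10000 nM in this assay, at which 1 of the 4 values shown sits.

From the compounds shown here alone, how a benzyl group carrying an amine or a carboxylic acid, or a longer chain on this nitrogen, would read in this assay stays open.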